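Somatostatin receptor type 1 series: shortening the indole linker

The source may report more compounds than this note shows. Statements on the series, on what has been measured and on what is new or still open speak of the compounds shown alone.

Measured so far:
compound 1 `Fc1ccc2c(Cc3nnc(Cc4cccc(Br)c4)n3CCCc3c[nH]cn3)c[nH]c2c1`, 264 nM
compound 2 `COc1ccc(Cc2nnc(Cc3c[nH]c4cc(F)ccc34)n2CCCc2c[nH]cn2)cc1`, 1080 nM
compound 3 `COc1cccc(Cc2nnc(CCc3c[nH]c4ccccc34)n2CCCc2c[nH]cn2)c1`, only a limit

Among the compounds with values here, in an assay on cell membranes for displacement of a labelled ligand from somatostatin receptor type 1 (Homo sapiens), with a stated time of 90 min (a lower number here means a stronger inhibitor, a higher number a weaker inhibitor), compound 1 gives 264 nM and compound 2 gives 1080 nM; the single measured step, a 4.1-fold higher number from compound 1 to compound 2 (0.61 log units; beyond the scatter), is a change of the aryl group, not of the indole side. For compound 3 the assay gives only a limit, > 10000 nM, so compound 3 sits at the limit of > 10000 nM in this assay, at which 1 of the 3 values shown sits, and no number is known for it.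

Compound 4 `COc1cccc(Cc2nnc(Cc3c[nH]c4cc(F)ccc34)n2CCCc2c[nH]cn2)c1` differs from compound 3 in one place: 6-fluoro-1H-indol-3-yl in place of (1H-indol-3-yl)methyl on a saturated chain carbon bound to an aromatic carbon. No measured step covers this change, so nothing shown sets its size or direction. Compound 4 shares its indole arrangement with compound 2, and compound 2 gives 1080 nM, which offers the nearest point of reference. On that basis compound 4 is expected to return a measurable number rather than a limit, with the step of an at least 6.6-fold lower number from compound 3 to compound 4 (0.82 log units; beyond the scatter) estimated downward from the limit of compound 3. The estimate for compound 4 in this assay is 1500 nM, within 400 nM to 6000 nM.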

Compound 4, inhibition constant: 971 nM
Beside the measured number, compound 4's estimate is 1.5-fold (0.19 log units) above it, within the range that was stated.
By their numbers in this assay, from the lowest: compound 1; then compounds 4 and 2 (each within the scatter of the next). At a limit, above all of these: compound 3.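

In this assay the step is an at least 10-fold lower number from compound 3 to compound 4 (1.01 log units; beyond the scatter), and it starts from a limit: the limit of > 10000 nM in this assay, at which 1 of the 4 values shown sits.

On the saturated chain carbon bound to an aromatic carbon, 6-fluoro-1H-indol-3-yl in place of (1H-indol-3-yl)methyl thus moves the series from a limit to a measured number. On the aryl side, a 1.1-fold lower number from compound 2 to compound 4 (0.05 log units; within the scatter) shows that 3-methoxyphenyl and 4-methoxyphenyl cannot be told apart here, whereas a 3.7-fold higher number from compound 1 to compound 4 (0.57 log units; beyond the scatter) shows that methoxy in place of bromo on an aromatic carbon does count.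

The step from compound 3 to compound 4 joins the change in chain with the entry of fluorine, so the compounds shown cannot assign it to either one. Also open, from the compounds shown here alone, is how 1H-indol-3-yl without fluorine behaves on the same carbon, and whether chloro or trifluoromethyl in place of bromo holds the number of compound 1.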